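This account rests on a few compounds, and the source may have more. Where it says the series, first, only, none or still open, it means among the compounds named here.

Compound 2 `CCOC(=O)C1=Cc2ccccc2OC1(OCc1cn(-c2cccc(C(F)(F)F)c2)nn1)C(F)(F)F` stands at the edge of what a functional assay on DU-145 cells (Homo sapiens) for inhibition, read by MTT assay, with a stated time of 24 h (on this read-out higher numbers stand for weaker inhibition and lower numbers for stronger inhibition), can report: in this assay compound 2 gives > 150000 nM, which is a limit and not a number. Compound 1 `CCOC(=O)C1=Cc2ccccc2OC1(OCc1cn(CC(=O)NC2CCCCC2)nn1)C(F)(F)F` gives 10200 nM in this assay, and the step of an at least 14-fold higher number from compound 1 to compound 2 (1.16 log units; beyond the scatter) reaches (the limit of > 150000 nM in this assay, at which 1 of the 2 values shown sits). Compound 3 `CCOC(=O)C1=Cc2ccccc2OC1(OCc1cn(-c2ccc([N+](=O)[O-])cc2)nn1)C(F)(F)F` differs from compound 2 by 4-nitrophenyl in place of 3-(trifluoromethyl)phenyl on an aromatic nitrogen. No measured step exchanges one aromatic group for another on that nitrogen, and the only step shown ended at a limit, so compound 3 is expected to move little, with a number no higher from compound 2 to compound 3 (the limit leaves the size open). Compound 3 is therefore estimated at 150000 nM, within a range from 30000 nM to 400000 nM.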

Compound 3, half-maximal inhibitory concentration: > 150000 nM
Compound 3 gave a limit, no number; the forecaster's own chance of this, stated with the estimate: 60%; the middle value lies on the limit itself.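

A second aromatic group on this nitrogen, 4-nitrophenyl, gives the same outcome in this assay as 3-(trifluoromethyl)phenyl, so the result no longer rests on one substituted phenyl ring: the limit of > 150000 nM in this assay, at which 2 of the 3 values shown sit. Compared with the (cyclohexylcarbamoyl)methyl group of compound 1, the change gives an at least 14-fold higher number from compound 1 to compound 3 (1.16 log units; beyond the scatter), and compound 1 remains the only one shown with a number. The step between compound 2 and compound 3 cannot be read, as both values are limits.

Going by these compounds, what remains open is how far past the limit these two compounds lie. On these data alone, it is also open whether a benzyl group, or a longer chain ending in an amine, on this nitrogen would return a readable number.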